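The source may hold more compounds than are shown below. What is called first, only, known or untested is meant among the compounds shown, and "the series" means these compounds.

Three compounds have been measured in an ADME assay on microsomes from liver (Homo sapiens) for metabolic stability, read by HPLC, using NADPH, with a stated time of 60 min, tested at 1 uM, in the presence of a further agent that is not named here; on this read-out lower numbers stand for slow clearance and higher numbers for fast clearance:

Compound 1, `Cc1cc(C(=O)NNS(=O)(=O)c2ccccc2F)cc(-n2cc(F)cn2)c1`, gives 143 uL/min.
Compound 2, `CCOc1cc(C)cc(C(=O)NNS(=O)(=O)c2ccccc2F)c1`, gives 181 uL/min.
Compound 3, `O=C(NNS(=O)(=O)c1ccccc1F)c1cccc(-n2cccn2)c1`, gives 12 uL/min.

Compound 3 has the lowest number of the three; the gaps from it to compound 1 and to compound 2 are both well beyond the usual scatter of repeated measurements, so it is the slowest-cleared compound here. For the measured compounds named here, compound 1 and compound 2 lie close together, and the only measured step, a 1.3-fold higher number from compound 1 to compound 2 (0.10 log units; within the scatter), is within the scatter.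

The next compound, compound 4, `O=C(NNS(=O)(=O)c1ccccc1F)c1cc(F)cc(-n2cccn2)c1`, differs from compound 3 in one place: fluoro in place of hydrogen on an aromatic carbon. Going by the values given here, no measured pair shows this same change, a fluoro entering for a hydrogen on the six-membered aromatic ring of carbon only, so nothing measured bears directly on it. The step from compound 1 to compound 2 concerns a different position and a different group, and it was small anyway. With no evidence of a shift, the expectation for compound 4 is a step of about a 1.3-fold higher number from compound 3 to compound 4 (0.10 log units; within the scatter) in this assay, which is to say no change beyond the scatter. Compound 4 is therefore estimated at 15 uL/min, with a range from 6 uL/min to 40 uL/min.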

Compound 4, intrinsic clearance in a liver preparation (reported as CLH), per the amount of preparation that the assay uses: 18 uL/min
Compound 4: middle estimate off by 1.2-fold (0.08 log units), on the low side; measured number inside the range.
By their numbers in this assay, from the lowest: compounds 3 and 4 (each within the scatter of the next); then compounds 1 and 2 (each within the scatter of the next).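

Swapping hydrogen for fluoro on this aromatic carbon, meta to the 1H-pyrazol-1-yl group, gives a 1.5-fold higher number from compound 3 to compound 4 (0.18 log units; within the scatter) in this assay and is the first measured change at this position. The earlier step between compounds concerned a different swap, ethoxy in place of 4-fluoro-1H-pyrazol-1-yl, so it said nothing about this carbon, whereas this pair shows that one added fluorine atom here does not move the clearance number beyond the usual scatter of repeats. That finding rests on a single pair, and nothing available explains the result.

On these data alone, a single fluoro says little about what a larger or different group on the same carbon would do, such as a methoxy, an amine or a carboxylic acid, so the limits of this position remain open. As far as these compounds go, it is also open whether the same fluoro would again leave the number within the scatter on a compound carrying the ethoxy group of compound 2, whose clearance number stands at 181 uL/min in this assay.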